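The compounds below may be only part of what the source reports. "The series", "measured", "known", "first", "only" and "open" are said of these compounds alone.

The set shares the core of compound 1 `CCCOc1ccc(C(=O)Nc2cccc(C)n2)cc1`, and in an in vitro assay on HEK-tsA201 cells for antagonist activity at Neuronal acetylcholine receptor; alpha4/beta2 (Homo sapiens), read by fluorescence and calcium flux (on this read-out lower numbers stand for stronger inhibition and higher numbers for weaker inhibition), compound 1 gives 7500 nM. Compound 2 `CCCNc1cccc(NC(=O)c2ccc(OCCC)cc2)n1` gives 15400 nM in this assay, the step being a 2.1-fold higher number from compound 1 to compound 2 (0.31 log units; beyond the scatter). Compound 3 `CCCOc1ccc(C(=O)Nc2cccc(Nc3ccc(F)cc3)n2)cc1` is reported only as a limit of this assay, > 100000 nM. Compound 3 thus stands at the limit of > 100000 nM in this assay, at which 1 of the 3 values shown sits, the weakest point the numbers reach. Measured from compound 1 the step is an at least 13-fold higher number from compound 1 to compound 3 (1.12 log units; beyond the scatter), and from compound 2 it is an at least 6.4-fold higher number from compound 2 to compound 3 (0.81 log units; beyond the scatter).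

Compound 4 `CCCOc1ccc(C(=O)Nc2cccc(N3CCCCC3)n2)cc1` differs from compound 3 by piperidin-1-yl in place of (4-fluorophenyl)amino on an aromatic carbon. Among the measured compounds shown here, two measured steps bear on this change. The step from compound 2 to compound 3, in which 4-fluorophenyl replaced propyl on the ring nitrogen, ran an at least 6.4-fold higher number from compound 2 to compound 3 (0.81 log units; beyond the scatter); compound 4 reverses that direction by returning to a saturated substituent on that nitrogen. The step from compound 1 to compound 2, which introduced a saturated amino group in place of methyl, was only a 2.1-fold higher number from compound 1 to compound 2 (0.31 log units; beyond the scatter). A step down in this assay is therefore expected, at least modest and likely large, placing compound 4 near compound 2.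

Compound 4 is estimated at 20000 nM in this assay, within 5000 nM to 80000 nM. That estimate means a step of an at least 5.0-fold lower number from compound 3 to compound 4 (0.69 log units; beyond the scatter), expected to bring compound 4 back inside the measurable range.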

Compound 4, half-maximal inhibitory concentration: > 100000 nM
Compound 4 gave a limit, no number; the forecaster's own chance of this, stated with the estimate: 15%; middle value at least 5.0-fold (0.69 log units) away from the limit.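

On the position that carries the methyl of compound 1, a saturated group does not by itself keep the compound in the measurable range of this assay: piperidin-1-yl in place of propylamino gives an at least 6.4-fold higher number from compound 2 to compound 4 (0.81 log units; beyond the scatter), and piperidin-1-yl in place of methyl gives an at least 13-fold higher number from compound 1 to compound 4 (1.12 log units; beyond the scatter). The loss seen with compound 3 is therefore not confined to an aromatic substituent, and the hydrogen-bond donor count does not sort the two compounds either, as (4-fluorophenyl)amino has one and piperidin-1-yl has none. Compound 3 and compound 4 are both reported only as limits, so the step between them cannot be read, and they share the end of the scale: the limit of > 100000 nM in this assay, at which 2 of the 4 values shown sit.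

The compounds shown leave open whether the measurable values of compound 1 and compound 2 fail with the ring in piperidin-1-yl or with the loss of the hydrogen on the attached nitrogen, a question that an open-chain dimethylamino group would address. On these data alone, whether a smaller pyrrolidin-1-yl ring would return to the measurable range also stays open.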